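Methoxy for Chloro on Two Related Alkyne Acids

This account rests on a few compounds, and the source may have more. Where it says the series, first, only, none or still open, it means among the compounds named here.

Compound 1 `O=C(O)CCc1ccc(C#Cc2ccnc(Cl)c2)cc1` and compound 3 `COc1cc(C#Cc2ccc(CCC(=O)O)cc2)ccn1` share one core; compound 2 `O=C(O)CCc1ccc(C#Cc2ccnc(Cl)n2)cc1` and compound 4 `COc1nccc(C#Cc2ccc(CCC(=O)O)cc2)n1` share another. The difference between the two cores is not broken down here. In an in vitro functional assay on 1321-N1 cells for agonist activity at Free fatty acid receptor 1 (Homo sapiens), read by fluorescence, spectrophotometry and calcium flux (a lower number here means a smaller maximal response, a higher number a larger maximal response), compound 1 gives 94%, compound 3 gives 98%, and compound 2 gives 131%, the highest of the three measured numbers and beyond the scatter from both others. The change from compound 1 to compound 3 is methoxy in place of chloro on an aromatic carbon, and it gave a number 4 percentage points higher from compound 1 to compound 3 (within the scatter). The change from compound 2 to compound 4 is methoxy in place of chloro on an aromatic carbon, the same kind of change but not the same: in compound 1 the group sits on a six-membered aromatic ring with 1 nitrogen, next to the ring nitrogen, while in compound 2 it sits on a six-membered aromatic ring with 2 nitrogen, between two ring nitrogen atoms. Because a number 4 percentage points higher from compound 1 to compound 3 (within the scatter) was within the scatter, a similarly small step is expected, a number 1 percentage points lower from compound 2 to compound 4 (within the scatter). Compound 4 is therefore estimated at 130%, with a likely range from 108% to 152%.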

Compound 4, largest response reached (reported as efficacy), in percent of the reference or control that the assay uses: 109%
For compound 4 the middle estimate is 21 percentage points above the measured one; the range from low to high includes it.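

In this assay, methoxy in place of chloro on the core of compound 2 gave a number 22 percentage points lower from compound 2 to compound 4 (beyond the scatter). Set beside the step on the other core, this result shows that the change did not carry over as one fixed step: the same change on two cores in this assay, a number 4 percentage points higher (within the scatter) from compound 1 to compound 3 and a number 22 percentage points lower (beyond the scatter) from compound 2 to compound 4, 26 percentage points apart, beyond the scatter of two such steps It does not show which feature of the two cores accounts for the gap, as the two pairs differ both in the ring that carries the group and in where the group sits on that ring, and a single pair on each core supports no general rule for the series.

The compounds shown leave open whether an amine or an ethoxy group in place of the chloro would also give steps that differ between these two cores. They also leave open how the same exchange of chloro for methoxy would behave on a third core.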